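The compounds below may be only part of what the source reports. "The series", "measured", "known", "first", "only" and "open" are said of these compounds alone.

Measured compounds:
- compound 1 `COc1ccc(Cc2nnc(NC(=O)/C(C#N)=C/c3ccccc3OS(=O)(=O)c3ccc(F)cc3)s2)cc1`: 6%
- compound 2 `N#C/C(=C\c1ccccc1OS(=O)(=O)c1ccccc1[N+](=O)[O-])C(=O)Nc1nnc(Cc2cccc3ccccc23)s1`: "not toxic" (no number reported)

Both results come from an ADME assay on HEK-293T cells (Homo sapiens) for inhibition, read by CCK-8 assay, with a stated time of 48 h, tested at 20 uM; on this read-out higher numbers stand for more inhibition of growth at the one concentration tested and lower numbers for less inhibition of growth. Among the compounds with values here, compound 2 has no single number here, so its standing rests on the verbal report alone, and no measured step links it to compound 1. The next compound is compound 3 `N#C/C(=C\c1ccccc1OS(=O)(=O)c1ccc(F)cc1)C(=O)Nc1nnc(Cc2cccc3ccccc23)s1`, with the change (4-fluorophenyl in place of 2-nitrophenyl on a sulfonyl sulfur). Compound 1 carries the same 4-fluorophenyl on a sulfonyl sulfur and gives 6%, so no step beyond the scatter is expected in this assay. The estimated value for compound 3 is 10%, with an expected range of 0% to 28%.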

Compound 3, percent growth inhibition at one concentration: 15%
Beside the measured number, compound 3's estimate is 5 percentage points below it, within the range that was stated.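

In this assay, within the data shown here, the exchange of 4-methoxyphenyl for naphthalen-1-yl on a saturated chain carbon bound to an aromatic carbon, with 4-fluorophenyl kept on the sulfonyl sulfur, gives a number 9 percentage points higher from compound 1 to compound 3 (within the scatter) as the only readable step. The step from 2-nitrophenyl to 4-fluorophenyl cannot be read, as compound 2 has only a verbal report. No evidence on the cause of these results is available. Going by these compounds, a dimethylamino group or a carboxylic acid on that chain carbon in place of the aromatic ring remains open in this assay as a test of this position.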